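Compound 2 gains a methoxy group

The source may report more compounds than this note shows. Statements on the series, on what has been measured and on what is new or still open speak of the compounds shown alone.

Compound 1 `Oc1cccc2ccc(-c3cc4cc(Cl)ccc4[nH]3)nc12`: 9.8 10^-6 cm/s
Compound 2 `Oc1ccc2[nH]c(-c3ccc4cccc(O)c4n3)cc2c1`: 14.8 10^-6 cm/s

In an ADME assay for permeability, using PAMPA, with a stated time of 10 h, tested at 100 ug/mL (a lower number here means that the compound crosses the layer more slowly, a higher number that the compound crosses the layer faster), compound 2 gives 14.8 10^-6 cm/s, within the scatter of compound 1 at 9.8 10^-6 cm/s. Compound 3 `COc1cc2[nH]c(-c3ccc4cccc(O)c4n3)cc2cc1O` carries methoxy in place of hydrogen on an aromatic carbon, ortho to a hydroxy group (methoxy in place of hydrogen on an aromatic carbon). Among the measured compounds shown here, only one measured step exists, a 1.5-fold higher number from compound 1 to compound 2 (0.18 log units; within the scatter), and it bears only loosely, since it exchanges other groups. With so little evidence, no change beyond the scatter is expected in this assay. The expected step is a 1.1-fold lower number from compound 2 to compound 3 (0.06 log units; within the scatter). Compound 3 is estimated at 13 10^-6 cm/s, with an expected range from 6 10^-6 cm/s to 26 10^-6 cm/s.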

Compound 3, apparent permeability: 12.1 10^-6 cm/s
The estimate for compound 3 lay 1.1-fold (0.03 log units) above the measured number, within the range that was stated.
By their numbers in this assay, from the lowest: compounds 1, 3 and 2 (each within the scatter of the next).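

With methoxy in place of hydrogen on this aromatic carbon, ortho to a hydroxy group, this assay shows a 1.2-fold lower number from compound 2 to compound 3 (0.09 log units; within the scatter). Among the compounds shown here, this is the first reading at this carbon, and it shows that adding methoxy here, with its two heavy atoms, brings no change beyond the scatter. No available measurement gives a reason for this result. The compounds shown leave open whether a larger group on this carbon, such as an amine or a longer alkoxy chain, would also stay within the scatter. They also leave open whether the outcome for methoxy would hold without the hydroxy group ortho to it.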